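Methyl in Place of Hydrogen on the Phenyl of Compound 3

This account rests on a few compounds, and the source may have more. Where it says the series, first, only, none or still open, it means among the compounds named here.

The measured compounds and their numbers in a functional assay on CHO cells for antagonist activity at adenosine receptor A2b (Homo sapiens); a lower number here means a stronger inhibitor, a higher number a weaker inhibitor:
Compound 1, `Nc1ncnc2c1nc(-c1ccco1)n2CCCO`, gives 350 nM.
Compound 2, `CCn1c(-c2ccco2)nc2c(N)ncnc21`, gives 375 nM.
Compound 3, `Cn1c(-c2ccco2)nc2c(NC(=O)Nc3ccccc3)ncnc21`, gives 6250 nM.

Of the three, compound 3 stands with the highest number in this assay, well beyond the scatter from compound 2 and from compound 1. The next compound is compound 4, `Cc1ccc(NC(=O)Nc2ncnc3c2nc(-c2ccco2)n3C)cc1`, which differs from compound 3 by methyl in place of hydrogen on an aromatic carbon.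

Among the measured compounds shown here, only one measured step exists, a 1.1-fold higher number from compound 1 to compound 2 (0.03 log units; within the scatter), and it concerns a saturated chain on the shared core, not the phenyl of the urea; it therefore bears little on the present change. For the measured compounds named here, there is no measured pair showing what a methyl on this aromatic carbon does. Given that, the step is expected to stay within the scatter, a 1.3-fold lower number from compound 3 to compound 4 (0.10 log units; within the scatter), in no firm direction. Compound 4 is estimated at 5000 nM in this assay, between 1800 nM and 14000 nM.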

Compound 4, inhibition constant: > 30000 nM
Compound 4 was reported as a limit; the forecaster's own chance of this, stated with the estimate: 10%; middle value at least 6.0-fold (0.77 log units) from the limit.
By their numbers in this assay, from the lowest: compounds 1 and 2 (each within the scatter of the next); then compound 3. At a limit, above all of these: compound 4.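

Compound 4 is reported only as a limit in this assay: the limit of > 30000 nM in this assay, at which 1 of the 4 values shown sits.

Even so, the change from phenyl to 4-methylphenyl can be read as a step, an at least 4.8-fold higher number from compound 3 to compound 4 (0.68 log units; beyond the scatter), and it lies beyond the scatter. Among the compounds shown here, the earlier compounds said nothing about the phenyl of the urea, and this pair shows that a single added methyl on this aromatic carbon, para to a large group, moves the compound towards weaker inhibition, not within the scatter as the one earlier step on the saturated chain did.

The compounds shown leave open whether this weakening belongs to methyl alone or would also follow from another group at the same carbon, such as fluorine, methoxy or a carboxylic acid. They also leave open what a methyl would do on another carbon of the same ring.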